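Aryl swap at the exocyclic double bond: fluorophenyl replaces thiophene

A few compounds are considered here, and "the series" means these few. Any claim that something is new, unique, unknown or untested is made for them only; others in the source may bear on it.

The compounds measured so far in a functional assay on A549 cells (Homo sapiens) for cytotoxicity, read by MTT assay, with a stated time of 24 h; a higher number here means a weaker inhibitor, a lower number a stronger inhibitor:
Compound 1, `COc1cc(/C=C2\SC(=O)N(Cc3ccc(C(=O)O)cc3)C2=O)cc(OC)c1OC`, gives 36000 nM.
Compound 2, `O=C(O)c1ccc(CN2C(=O)S/C(=C\c3ccccn3)C2=O)cc1`, gives 80000 nM.
Compound 3, `O=C(O)c1ccc(CN2C(=O)S/C(=C\c3cccs3)C2=O)cc1`, gives 80000 nM.

Compound 3 stands level with compound 2 on these numbers, the two together at the top, while compound 1 sits beyond the scatter lower. Compound 4, `O=C(O)c1ccc(CN2C(=O)S/C(=C\c3ccc(F)cc3)C2=O)cc1`, differs from compound 3 by 4-fluorophenyl in place of thiophen-2-yl on a double-bonded chain carbon bound to a double-bonded ring carbon. Within the data shown here, the one measured step at this place, no change at the digits printed from compound 2 to compound 3 (within the scatter), showed no change within the scatter, so a ring swap there has not moved this assay. Among the measured compounds shown here, compound 1 carries a six-membered carbon ring at the same place and gives a lower number, but no single step links it to compound 3. Compound 4 is therefore expected at most a small step, a 1.3-fold lower number from compound 3 to compound 4 (0.12 log units; within the scatter), and is estimated at 60000 nM, between 25000 nM and 120000 nM.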

Compound 4, half-maximal inhibitory concentration: 36000 nM
Compound 4: middle estimate off by 1.7-fold (0.22 log units), on the high side, within the range that was stated.
By their numbers in this assay, from the lowest: compounds 1 and 4 (each within the scatter of the next); then compounds 2 and 3 (each within the scatter of the next).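

In this assay this position can move the number after all: the swap gives a 2.2-fold lower number from compound 3 to compound 4 (0.35 log units; beyond the scatter) and also a 2.2-fold lower number from compound 2 to compound 4 (0.35 log units; beyond the scatter) as modest steps, whereas the earlier exchange of one ring for another left the number unchanged. Among these compounds the two carrying a six-membered aromatic ring of carbon only give the lower numbers, and compound 4 matches compound 1 at 36000 nM on the printed digits. No measurement at hand explains the step.

Still open, from the compounds shown here alone, is whether the fluorine matters or the carbon ring alone suffices, a question that plain phenyl, 4-chlorophenyl or 4-aminophenyl at this place would answer.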